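The source may hold more compounds than are shown below. What is called first, only, known or untested is meant among the compounds shown, and "the series" means these compounds.

Compound 1 `O=C(Nc1cccc(-c2ccoc2)c1)C(Cl)Cl` and compound 2 `O=C(Nc1cccc(-c2ccccc2Cl)c1)C(Cl)Cl` share one core and differ only in the ring attached to it. Both were examined in a functional assay on KB 3-1 cells (Homo sapiens) for cytotoxicity, read by MTT assay, with a stated time of 68 h; on this read-out higher numbers stand for weaker inhibition and lower numbers for stronger inhibition. In this assay compound 1 gives > 50000 nM, which is a limit of the assay rather than a number. Compound 2 in turn gives > 50000 nM, again a limit and not a measured number. Where compound 2 stands on the numbers shown is therefore simple: it sits at the limit of > 50000 nM in this assay, at which 2 of the 2 values shown sit, and no value shown separates it from compound 1.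

Compound 3 `O=C(Nc1cccc(-c2ccccc2F)c1)C(Cl)Cl` follows from compound 2 through the change (fluoro in place of chloro on an aromatic carbon). Among the measured compounds shown here, no step between two measured compounds is available to guide this change, so the expectation rests on the two limits alone. The step that the limit leaves unreadable from compound 2 to compound 3 in this assay is expected to be none beyond the scatter, in no particular direction. Compound 3 is accordingly estimated at about 60000 nM, with a range from 25000 nM to 150000 nM, and it is expected that the assay will most likely again report only a limit for it.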

Compound 3, half-maximal inhibitory concentration: 48300 nM
For compound 3 the middle estimate is 1.2-fold (0.09 log units) above the measured one; measured number inside the range.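

Compound 3, with fluoro in place of chloro on an aromatic carbon ortho to a large group, gives 48300 nM in this assay, the only actual number among the three compounds shown, so this position can yield a reading inside the range of the assay. The change itself can be read only as a floor: an at least 1.0-fold lower number from compound 2 to compound 3 (0.01 log units; that floor lies within the scatter). That floor does not show that fluoro and chloro differ at this position, and the values shown still cluster at a single limit: the limit of > 50000 nM in this assay, at which 2 of the 3 values shown sit.

Going by these compounds, the true size of the step stays open, as compound 2 carries only a limit and the step can be stated only as a floor. Also open, on these data alone, is whether another group on this aromatic carbon, such as an amine, a methoxy group or a carboxylic acid, would give a number clearly beyond the scatter from that of compound 3 in this assay.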